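The compounds below may be only part of what the source reports. "The series", "measured", "known", "first", "only" and "open" are said of these compounds alone.

Of the compounds shown here, three of a shared core have been measured. In a functional assay on MCF7 cells (Homo sapiens) for cytotoxicity, read by MTT assay, with a stated time of 48 h (on this read-out lower numbers stand for stronger inhibition and higher numbers for weaker inhibition), compound 1 `COc1ccc(/C=C2\N=C(c3ccc(C)cc3)N(C(=O)c3nc4c(c(C)nn4-c4ccccc4)c(=O)[nH]3)NC2=O)cc1` gives 17.3 nM, compound 2 `Cc1nn(-c2ccccc2)c2nc(C(=O)N3NC(=O)/C(=C/c4ccccc4)N=C3c3ccc(Cl)cc3)[nH]c(=O)c12` gives 12.3 nM, and compound 3 `Cc1nn(-c2ccccc2)c2nc(C(=O)N3NC(=O)/C(=C/c4ccc(Cl)cc4)N=C3c3ccc(Cl)cc3)[nH]c(=O)c12` gives 17.8 nM; compound 3 carries the highest of the three numbers, yet every gap to it lies within the scatter, so nothing separates them. Compound 4 `COc1ccc(/C=C2\N=C(c3ccc(Cl)cc3)N(C(=O)c3nc4c(c(C)nn4-c4ccccc4)c(=O)[nH]3)NC2=O)cc1` differs from compound 3 by methoxy in place of chloro on an aromatic carbon. Going by the values given here, no measured step swaps exactly these two groups; the nearest comparison is a 1.4-fold higher number from compound 2 to compound 3 (0.16 log units; within the scatter), which altered the same carbon without moving the number beyond the scatter. Compound 1 already holds the methoxy group and sits beside compound 3 in value. Compound 4 is therefore expected to change by a 1.2-fold lower number from compound 3 to compound 4 (0.07 log units; within the scatter) at most, with an estimate of 15 nM and a range from 8 nM to 35 nM.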

Compound 4, half-maximal inhibitory concentration: 32.9 nM
Estimate against measurement, compound 4: 2.2-fold (0.34 log units) below; low and high end bracket the measured number.
By their numbers in this assay, from the lowest: compounds 2, 1, 3 and 4 (each within the scatter of the next, the first and the last beyond it).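

Going by these compounds alone, at this position, on a six-membered aromatic ring of carbon only, methoxy gives the first step beyond the scatter (a 2.7-fold higher number from compound 2 to compound 4 (0.43 log units; beyond the scatter)), a modest one, while chloro did not (a 1.4-fold higher number from compound 2 to compound 3 (0.16 log units; within the scatter)). Methoxy and chloro are not separated from each other (a 1.8-fold higher number from compound 3 to compound 4 (0.27 log units; within the scatter)), and chloro in place of methyl at another aromatic carbon also stays within the scatter (a 1.9-fold higher number from compound 1 to compound 4 (0.28 log units; within the scatter)). Nothing available explains these steps. Going by these compounds, whether an amine, a hydroxyl or a longer chain such as butoxy at this carbon would shift the number further remains open.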